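The source may report more compounds than this note shows. Statements on the series, on what has been measured and on what is new or still open speak of the compounds shown alone.

Of the compounds shown here, two that share the same atoms and bonds have been measured: compound 1 `O=C(c1ccc(O)cc1O)[C@H]1[C@H](c2ccccc2)[C@H](C(=O)c2ccc(O)cc2O)[C@@H]1c1ccccc1` and compound 2 `O=C(c1ccc(O)cc1O)[C@@H]1[C@@H](C(=O)c2ccc(O)cc2O)[C@H](c2ccccc2)[C@@H]1c1ccccc1`. In a functional assay on PC-3 cells (Homo sapiens) for cytotoxicity, read by MTT assay, with a stated time of 48 h, tested at 25 uM (on this read-out higher numbers stand for a stronger effect at the one concentration tested and lower numbers for a weaker effect), compound 1 gives 57.9%. In this assay compound 2 gives 75.5%, the highest of the two numbers; the nearest is compound 1, whose number sits lower by more than the usual scatter. Compound 3 `O=C(c1ccc(O)cc1O)[C@@H]1[C@@H](C(=O)c2ccc(O)cc2O)[C@H](c2ccccc2)[C@H]1c1ccccc1` has not yet been measured in this assay. Set against compound 2, the change is this: the two compounds have the same atoms and bonds and differ only in configuration as drawn: 1 of 4 stereo elements differ; a stereocentre at a saturated ring carbon is drawn S in compound 2 and R in compound 3. For the measured compounds named here, no step between two measured compounds is given here, so these data do not show how large an effect such a change of configuration alone has; the two measured values only show that compounds of identical atoms and bonds can differ beyond the scatter. A modest downward step is therefore expected, a number 12.5 percentage points lower from compound 2 to compound 3 (beyond the scatter). For compound 3 in this assay the estimate is 63%, with a range from 45% to 80%.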

Compound 3, a percentage reported as activity, at one concentration (the size of the read-out at that concentration, not a potency): 96.3%
Estimate against measurement, compound 3: 33.3 percentage points below; measured number above the stated range.
By their numbers in this assay, from the lowest: compound 1; then compound 2; then compound 3.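

Changing one stereocentre at a saturated ring carbon from S to R gives a number 20.8 percentage points higher from compound 2 to compound 3 (beyond the scatter) in this assay. This is the first step shown that isolates a single change of configuration, and it shows that the drawn configuration at this one ring carbon can by itself shift the read-out beyond the scatter, with no atom or bond entering or leaving. The step can be assigned to this one centre because of a single fact: the fact that compounds 2 and 3 differ only in the configuration as drawn

The compounds shown leave open whether changing the configuration at any of the other stereocentres alone would shift the number, and in which direction. They also leave open how this configuration would fare with a different group on the shared core, such as an amine or a methoxy group in place of a hydroxyl.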